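A methyl shift from compound 2 to compound 3

The source may hold more compounds than are shown below. What is called first, only, known or untested is meant among the compounds shown, and "the series" means these compounds.

compound 1 `O=c1cc(Cc2c(F)cccc2F)nc(N2CCCCC2)[nH]1` gives > 82000 nM as a limit
compound 2 `CC1CCCCN1c1nc(Cc2c(F)cccc2F)cc(=O)[nH]1` gives > 78000 nM as a limit

Both values come from an ADME assay on MT4 cells (Homo sapiens) for cytotoxicity, read by MTT assay, with a stated time of 4 days (a higher number here means that more compound is tolerated, a lower number that less compound is tolerated), and both are limits, not numbers. Compound 2 stands at the limit of > 78000 nM in this assay, at which 1 of the 2 values shown sits, and has no exact value.

Compound 3 `CC1CCCN(c2nc(Cc3c(F)cccc3F)cc(=O)[nH]2)C1` has the same atoms as compound 2, joined differently: 3-methylpiperidin-1-yl in place of 2-methylpiperidin-1-yl on an aromatic carbon. In words, 3-methylpiperidin-1-yl takes the place of 2-methylpiperidin-1-yl on an aromatic carbon.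

Going by the values given here, only one measured step bears on this change: a step that the two limits leave unreadable from compound 1 to compound 2 with a methyl in place of hydrogen on a saturated ring carbon. No size or direction can be carried over from it, so no change beyond the scatter is expected in this assay and the expected result is a number no higher from compound 2 to compound 3 (the limit leaves the size open) with neither direction favoured. Another limit rather than a number is the likely report. Compound 3 is estimated at 78000 nM with an expected range from 35000 nM to 130000 nM in this reading.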

Compound 3, half-maximal cytotoxic concentration: > 78000 nM
Compound 3 gave a limit, no number; the forecaster's own chance of this, stated with the estimate: 85%; the middle value lies on the limit itself.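

Going by these compounds alone, compound 1, compound 2 and compound 3 are all reported only as limits in this assay, so no step among them can be read. Where their true values lie, and whether 3-methylpiperidin-1-yl in place of 2-methylpiperidin-1-yl changes anything in this cell test, stays open.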